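Removing the Fluoro Group from Compound 3

A few compounds are considered here, and "the series" means these few. Any claim that something is new, unique, unknown or untested is made for them only; others in the source may bear on it.

Of the compounds shown here, three sharing one core have been measured in an ADME assay on microsomes from liver (Rattus norvegicus) for metabolic stability, with a stated time of 30 min, tested at 1 uM; on this read-out lower numbers stand for a less stable compound and higher numbers for a more stable compound. Compound 1 `CC[C@@H]1C(=O)N(C)c2cnc(-n3ccnc3-c3ccccc3)nc2N1[C@@H]1CCOC1` gives 0%, and compound 2 `CC[C@@H]1C(=O)N(C)c2cnc(-n3ccnc3-c3ccccc3)nc2N1C1CCCC1` gives 0%. Compound 3 `CC[C@@H]1C(=O)N(C)c2cnc(-n3ccnc3-c3ccc(F)cc3)nc2N1CCC(F)(F)F` gives 30%, the highest of the three numbers and beyond the scatter from both of the others.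

The next compound, compound 4 `CC[C@@H]1C(=O)N(C)c2cnc(-n3ccnc3-c3ccccc3)nc2N1CCC(F)(F)F`, has hydrogen in place of fluoro on an aromatic carbon of compound 3, turning 4-fluorophenyl into phenyl: hydrogen in place of fluoro on an aromatic carbon.

For the measured compounds named here, no measured step makes this same change. Going by the values given here, the only measured step is no change at the digits printed from compound 1 to compound 2 (within the scatter), with cyclopentyl in place of oxolan-3-yl, and it lies elsewhere on the molecule. It therefore says nothing direct about the fluoro group. A weaker hint comes from the phenyl that compound 4 will share with compound 1 at 0% and compound 2 at 0%. Those two also differ from compound 4 in the group on the nitrogen, which compound 4 shares with compound 3, so the comparison is not clean.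

A moderate fall is expected in this assay, estimated as a number 15 percentage points lower from compound 3 to compound 4 (beyond the scatter). For compound 4 the estimated value is 15%, with an expected range from 2% to 35%.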

Compound 4, percent of the compound remaining: 0%
For compound 4 the middle estimate is 15 percentage points above the measured one; the measured number lies below the stated range.
By their numbers in this assay, from the lowest: compounds 1, 2 and 4 (each within the scatter of the next); then compound 3.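

In this assay, for the compounds shown here, the first measured change at this aromatic carbon, para to a large group, gives a number 30 percentage points lower from compound 3 to compound 4 (beyond the scatter) on going from 4-fluorophenyl to phenyl, so the fluoro group matters here when 3,3,3-trifluoropropyl sits on the nitrogen. With phenyl in place, the group on the nitrogen does not separate the compounds, with no change at the digits printed from compound 2 to compound 4 (within the scatter) for 3,3,3-trifluoropropyl in place of cyclopentyl and no change at the digits printed from compound 1 to compound 4 (within the scatter) for the same group in place of oxolan-3-yl, so 3,3,3-trifluoropropyl alone gives no measurable gain over either ring on this phenyl series. The data shown offer no measurement that accounts for the effect of the fluoro group.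

The compounds shown leave open whether 4-fluorophenyl would raise the number with cyclopentyl or oxolan-3-yl on the nitrogen, or whether the rise seen in compound 3 needs both the fluoro group and 3,3,3-trifluoropropyl. They also leave open whether chloro, methoxy or a nitrile at the same aromatic carbon would match, exceed or fall short of the fluoro group in this assay on this core.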